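Sulfonyl aryl variation in a kallikrein-7 series

The source may report more compounds than this note shows. Statements on the series, on what has been measured and on what is new or still open speak of the compounds shown alone.

Among the measured compounds shown here, compound 2 `CC1=NC(c2cn(S(=O)(=O)c3ccccc3C)c3ccc(C)cc23)CN1` gives 1000 nM in an assay on isolated protein for inhibition of kallikrein-7 (Homo sapiens), read by fluorescence, with stated times of 10 min and 30 min (a lower number here means a stronger inhibitor, a higher number a weaker inhibitor), one of two numbers so far; compound 1 `CC1=NC(c2cn(S(=O)(=O)c3ccc(Cl)cc3)c3ccc(C)cc23)CN1` gives 1900 nM, and the step of a 1.9-fold lower number from compound 1 to compound 2 (0.28 log units; within the scatter) lies within the scatter. Compound 3 `CC1=NC(c2cn(S(=O)(=O)c3c(Cl)cccc3Cl)c3ccc(C)cc23)CN1` carries 2,6-dichlorophenyl in place of 2-methylphenyl on a sulfonyl sulfur. For the measured compounds named here, the only measured step also exchanged the aryl group on the sulfonyl sulfur and stayed within the scatter, so for compound 3 the step of no change at the digits printed from compound 2 to compound 3 (within the scatter) is expected to stay within the scatter as well. Compound 3 is therefore estimated at 1000 nM in this assay, with a range from 300 nM to 3500 nM.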

Compound 3, half-maximal inhibitory concentration: 14000 nM
Beside the measured number, compound 3's estimate is 14-fold (1.15 log units) below it; the whole stated range lies below it.
By their numbers in this assay, from the lowest: compounds 2 and 1 (each within the scatter of the next); then compound 3.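

The aryl group on the sulfonyl sulfur is not an indifferent place in this assay: 2,6-dichlorophenyl brings a 14-fold higher number from compound 2 to compound 3 (1.15 log units; beyond the scatter) and a 7.4-fold higher number from compound 1 to compound 3 (0.87 log units; beyond the scatter), although the exchange of 2-methylphenyl for 4-chlorophenyl stayed within the scatter. Exchanges at this place can therefore move the number well beyond the scatter. No evidence on the origin of this loss is available. Open, as far as these compounds go, is how an amine or a carboxylic acid on this aryl group would fare, and whether a smaller or larger sulfonyl substituent, such as a methyl group, would lower the number.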